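The compounds below may be only part of what the source reports. "The series", "measured", "known", "first", "only" and "open" are said of these compounds alone.

Working notes on the coumarin-derived series, antiproliferative arm.

Among the measured compounds shown here, compound 1 `COc1ccc(-c2c(Nc3ccc(F)cc3)c3ccccc3oc2=O)cc1` is the only member with a number in a functional assay on PANC-1 cells (Homo sapiens) for antiproliferative activity, read by MTT assay, with a stated time of 48 h; on this read-out higher numbers stand for weaker inhibition and lower numbers for stronger inhibition: in this read-out compound 1 gives 32000 nM, a weak result. Compound 2 `COc1ccc(-c2c(Nc3ccc(F)cc3)c3ccc(OC)cc3oc2=O)cc1` carries an additional methoxy on the shared core; in this assay compound 2 is recorded as "not determined" (no result reported), so there is no single number for where it stands, and the only anchor in the series remains the weak value of compound 1.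

Compound 3 `COc1ccc(-c2c(Nc3cccc(C(F)(F)F)c3)c3ccc(OC)cc3oc2=O)cc1` differs from compound 2 in one place: 3-(trifluoromethyl)phenyl in place of 4-fluorophenyl on a nitrogen on an aromatic ring. For the measured compounds named here, no step between two measured compounds is available for this change or for the methoxy addition, so the size and direction of the move from compound 2 to compound 3 in this assay cannot be read from the data. With compound 1 at 32000 nM as the sole reference, the expectation is that compound 3 stays in a similarly weak region, with no shift beyond the scatter assumed in either direction. Compound 3 is therefore estimated at 20000 nM in this assay, with a range from 5000 nM to 80000 nM.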

Compound 3, half-maximal inhibitory concentration: 39500 nM
Compound 3: middle estimate off by 2.0-fold (0.30 log units), on the low side; the measured number falls inside the stated range.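

In this assay compound 3 gives 39500 nM while compound 2 has no single number, so no new step can be read between compound 2 and compound 3. No evidence bears on this result. The compounds shown leave open whether 3-(trifluoromethyl)phenyl in place of 4-fluorophenyl, or the additional methoxy on the shared core, changes antiproliferative activity.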